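A Third Methoxy Group on the Pendant Phenyl Ring

The source may hold more compounds than are shown below. What is called first, only, known or untested is meant among the compounds shown, and "the series" means these compounds.

Compound 1 `COc1ccc(C2=NN(c3ccc(-c4ccccc4)nn3)C(c3ccc(F)cc3)C2)cc1` is the only one of the three measured compounds with a real number in a functional assay on Caco-2 cells (Homo sapiens) for antiproliferative activity, read by MTT assay, with a stated time of 24 h (on this read-out lower numbers stand for stronger inhibition and higher numbers for weaker inhibition), where compound 1 gives 18100 nM. Compound 2 `COc1ccc(C2=NN(c3ccc(-c4ccccc4)nn3)C(c3ccc(OC)cc3)C2)cc1` reaches only a limit of this assay, giving > 100000 nM. Compound 3 `COc1ccc(C2=NN(c3ccc(-c4ccccc4)nn3)C(c3ccc(OC)cc3OC)C2)cc1` likewise reaches only a limit, giving > 100000 nM. Both swaps toward methoxy weakened activity: an at least 5.5-fold higher number from compound 1 to compound 2 (0.74 log units; beyond the scatter) and an at least 5.5-fold higher number from compound 1 to compound 3 (0.74 log units; beyond the scatter), while a step that the two limits leave unreadable from compound 2 to compound 3. Compound 4 `COc1ccc(C2=NN(c3ccc(-c4ccccc4)nn3)C(c3cc(OC)c(OC)c(OC)c3)C2)cc1` carries a trimethoxyphenyl in place of the dimethoxyphenyl: 3,4,5-trimethoxyphenyl in place of 2,4-dimethoxyphenyl on a saturated ring carbon. Because both methoxy-bearing compounds sit at the limit of > 100000 nM in this assay, at which 2 of the 3 values shown sit, compound 4 is expected to remain weak as well. The estimate for compound 4 is 100000 nM, within 30000 nM to 300000 nM, meaning an expected a number no higher from compound 3 to compound 4 (the limit leaves the size open).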

Compound 4, half-maximal inhibitory concentration: > 100000 nM
Compound 4 gave a limit, no number (the forecaster's own chance of this, stated with the estimate: 70%); the middle value lies on the limit itself.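

On this saturated ring carbon, the 3,4,5-trimethoxyphenyl group gives no measurable number in this assay, so a third methoxy group in a new arrangement does not restore activity. Set against the 4-fluorophenyl group, this change gives an at least 5.5-fold higher number from compound 1 to compound 4 (0.74 log units; beyond the scatter). The steps among compound 2, compound 3 and compound 4 cannot be read, as all three stop at a limit: the limit of > 100000 nM in this assay, at which 3 of the 4 values shown sit.

As far as these compounds go, how far these three compounds lie beyond that limit stays open. So does whether a phenyl ring carrying an amine or a carboxylic acid would give a number in this assay.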